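From Compound 3 to Compound 4: An Aryl Exchange

This account rests on a few compounds, and the source may have more. Where it says the series, first, only, none or still open, it means among the compounds named here.

Compound 1, `O=C1COc2ccc(NC(=O)C3CCN(c4cccc(Br)c4)CC3)cc2N1`: in a functional assay for antagonist activity at transient receptor potential cation channel subfamily V member 1 (Homo sapiens), read by FLIPR and calcium flux (on this read-out lower numbers stand for stronger inhibition and higher numbers for weaker inhibition), compound 1 gives 330 nM.
Compound 2, `COc1cccc(N2CCC(C(=O)Nc3ccc4c(c3)NC(=O)CO4)CC2)c1`: compound 2 gives 1420 nM.
Compound 3, `O=C1COc2ccc(NC(=O)C3CCN(c4ccccc4C(F)(F)F)CC3)cc2N1`: compound 3 gives 380 nM.

Among these three numbers compound 3 stands second highest. Its nearest neighbour is compound 1, with a 1.2-fold higher number from compound 1 to compound 3 (0.06 log units; within the scatter), a step that lies within the scatter. Its furthest is compound 2, with a 3.7-fold lower number from compound 2 to compound 3 (0.57 log units; beyond the scatter), a modest step beyond the scatter. The step of a 4.3-fold higher number from compound 1 to compound 2 (0.63 log units; beyond the scatter) shows the same split from the other side.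

Compound 4, `Cc1c(Cl)cccc1N1CCC(C(=O)Nc2ccc3c(c2)NC(=O)CO3)CC1`, differs from compound 3 in one place: 3-chloro-2-methylphenyl in place of 2-(trifluoromethyl)phenyl on an amine nitrogen in a ring. Among the measured compounds shown here, two measured steps bear on this. The change from compound 1 to compound 3 exchanged one aryl group for another on the same ring nitrogen and stayed within the scatter; the change from compound 2 to compound 3 was a modest step, and compound 2 is the only one of the three that carries a methoxy group on that ring. Compound 4, like compound 1, carries a halogen on the aryl ring, so no step beyond the scatter is expected, a 1.1-fold lower number from compound 3 to compound 4 (0.04 log units; within the scatter). Compound 4 is therefore estimated at 350 nM, with a range from 150 nM to 900 nM.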

Compound 4, half-maximal inhibitory concentration: 100 nM
For compound 4 the middle estimate is 3.5-fold (0.54 log units) above the measured one, outside the stated range (below it).
By their numbers in this assay, from the lowest: compound 4; then compounds 1 and 3 (each within the scatter of the next); then compound 2.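

In this assay, the aryl group on the ring nitrogen proves able to move the number well below the level shared by compound 1 and compound 3: the exchange gives a 3.8-fold lower number from compound 3 to compound 4 (0.58 log units; beyond the scatter) and, against the other two aryl groups, a 3.3-fold lower number from compound 1 to compound 4 (0.52 log units; beyond the scatter) and a 14-fold lower number from compound 2 to compound 4 (1.15 log units; beyond the scatter) as well. A halogen on the aryl ring does not by itself set the number at this position, since compound 1 and compound 4 both carry one yet are separated beyond the scatter, and the 3-chloro-2-methylphenyl group, with fewer heavy atoms than the 2-(trifluoromethyl)phenyl group, gives the lowest number of the four compounds. Nothing available here accounts for this gain.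

The compounds shown leave open how the number responds to a 3-chlorophenyl group or a 2-methylphenyl group alone on the ring nitrogen, and so whether the chlorine, the methyl or the two together carry the change. Also open, on these data alone, is what a 2,3-dichlorophenyl group or a pyridine ring would give in the same place on the shared core.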